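This account rests on a few compounds, and the source may have more. Where it says the series, first, only, none or still open, it means among the compounds named here.

Measured so far in an assay on Prostate gland for inhibition of steroid 5-alpha-reductase (Rattus norvegicus); on this read-out lower numbers stand for stronger inhibition and higher numbers for weaker inhibition:
compound 1 `CCCCCn1ccc2cc(/C(C)=C/C(=O)Nc3ccccc3OCCCC(=O)O)ccc21` — 23 nM
compound 2 `CCCC(C(C)C)n1ccc2cc(/C(C)=C/C(=O)Nc3ccccc3OCCCC(=O)O)ccc21` — 7.2 nM
compound 3 `C/C(=C\C(=O)Nc1ccccc1OCCCC(=O)O)c1ccc2c(ccn2Cc2cccc(C)c2)c1` — 250 nM

Compound 1 stands second highest of the three numbers. Toward compound 2 the step is a 3.2-fold lower number from compound 1 to compound 2 (0.50 log units; beyond the scatter); toward compound 3 it is an 11-fold higher number from compound 1 to compound 3 (1.04 log units; beyond the scatter), and from compound 2 the same end point is reached with a 35-fold higher number from compound 2 to compound 3 (1.54 log units; beyond the scatter).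

Compound 4 `COc1ccc(Cn2ccc3cc(/C(C)=C/C(=O)Nc4ccccc4OCCCC(=O)O)ccc32)cc1` is not yet measured. Its difference from compound 1:
4-methoxyphenyl in place of butyl on a saturated chain carbon bound to an aromatic nitrogen
Among the measured compounds shown here, the one measured step at this place is the one from compound 1 to compound 3, where 3-methylphenyl entered in place of butyl on a saturated chain carbon bound to an aromatic nitrogen, and the number rose by an 11-fold higher number from compound 1 to compound 3 (1.04 log units; beyond the scatter). Compound 4 puts 4-methoxyphenyl at the same place, so a large step in the same direction, toward a weaker number, is expected: a 9.6-fold higher number from compound 1 to compound 4 (0.98 log units; beyond the scatter). For the measured compounds named here, no measured pair separates the 4-methoxyphenyl from the 3-methylphenyl case, so the range is kept wide. For compound 4 in this assay the expected value is 220 nM, between 70 nM and 700 nM.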

Compound 4, half-maximal inhibitory concentration: 480 nM
The estimate for compound 4 lay 2.2-fold (0.34 log units) below the measured number, and the stated range covers the measured number.
By their numbers in this assay, from the lowest: compound 2; then compound 1; then compounds 3 and 4 (each within the scatter of the next).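

In this assay, the rise seen with 3-methylphenyl recurs with 4-methoxyphenyl in place of butyl on a saturated chain carbon bound to an aromatic nitrogen, as a 21-fold higher number from compound 1 to compound 4 (1.32 log units; beyond the scatter) shows, so it is not tied to that one aryl group. The step between the two aryl groups, a 1.9-fold higher number from compound 3 to compound 4 (0.28 log units; within the scatter), does not separate them, while the distance from the branched 1-isopropylbutyl group is a 67-fold higher number from compound 2 to compound 4 (1.82 log units; beyond the scatter) and both aryl compounds sit on the weak side of both alkyl compounds, with none of the four going against this. No supporting data bear on the reason for this gap.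

The compounds shown do not tell whether the aromatic ring itself carries the loss, which a plain benzyl or a cyclohexylmethyl group would address. A 4-methylbenzyl group would separate the identity of the ring substituent from its location.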